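A few compounds are considered here, and "the series" means these few. Any claim that something is new, unique, unknown or untested is made for them only; others in the source may bear on it.

Measured so far:
- compound 1, `Clc1ccc2c(c1-c1ccn[nH]1)CCC2c1ncc[nH]1` — 40%
- compound 2, `Cc1oncc1-c1cccc2c1CCC2c1ncc[nH]1` — 63%
- compound 3, `c1ccc2c(c1)CCCC2c1ncc[nH]1` — 71%

All three numbers come from a functional assay on CHO cells for agonist activity at Alpha-1A adrenergic receptor (Homo sapiens), read by FLIPR and calcium flux; on this read-out lower numbers stand for smaller maximal responses and higher numbers for larger maximal responses. On this read-out compound 2 stands second highest of the three. Its nearest neighbour is compound 3, whose number lies a little higher, but the gap between compound 2 and compound 3 is within the scatter, so the two cannot be ordered. Compound 1 is the furthest away, with a number well below that of compound 2, and that gap is beyond the scatter. No two of the measured compounds differ in only one place, so no single step can be read from the data.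

Compound 4, `COc1cccc2c1CCC2c1ncc[nH]1`, has not yet been measured in this assay. It differs from compound 2 as follows: methoxy in place of 5-methyl-1,2-oxazol-4-yl on an aromatic carbon. With nothing in the series that isolates this change, the expectation rests on the spread of the measured numbers alone. A step of a number 2 percentage points higher from compound 2 to compound 4 (within the scatter) is expected from compound 2 to compound 4, which is to say no shift beyond the scatter in either direction. Compound 4 is therefore estimated at 65% in this assay, with a range from 45% to 85%.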

Compound 4, largest response reached (Emax), in percent of the reference or control that the assay uses: 65%
Beside the measured number, compound 4's estimate shows no gap at the digits printed; measured number inside the range.
By their numbers in this assay, from the lowest: compound 1; then compounds 2, 4 and 3 (each within the scatter of the next).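

In this assay the swap at this aromatic carbon, ortho to a fused ring and meta to a fused ring, gives a number 2 percentage points higher from compound 2 to compound 4 (within the scatter) for methoxy in place of 5-methyl-1,2-oxazol-4-yl, and this is the only single-place comparison among the compounds shown. Within this pair, one five-membered aromatic ring with 2 hetero atoms and 6 heavy atoms gives way to a group with no ring and 2 heavy atoms, with no shift in maximal response beyond the scatter, so the ring of the leaving group is not needed for a response of this size. No measured property of either compound bears on this result, so the data offer no explanation for it.

Still open, going by these compounds, is how far this tolerance extends at the same carbon, for example to an amine, a carboxylic acid or a longer chain such as butoxy, since two groups that match within the scatter do not define the limits of the position. Compound 1 and compound 3 each differ from compound 2 and compound 4 in more than one place, so their steps cannot be read, and the effects of the other structural differences in the series remain unresolved.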